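This account rests on a few compounds, and the source may have more. Where it says the series, first, only, none or still open, it means among the compounds named here.

Of the compounds shown here, three sharing one core have been tested in a functional assay on DU-145 cells (Homo sapiens) for antiproliferative activity, read by MTT assay, with a stated time of 48 h; on this read-out lower numbers stand for stronger inhibition and higher numbers for weaker inhibition. Compound 1 (`COc1cccc(/C=C/C(=O)N2Cc3ccccc3[C@@H](OCc3ccccc3)[C@@H]2CO)c1OC`) gives 29900 nM, and compound 2 (`COc1cc(/C=C/C(=O)N2Cc3ccccc3[C@@H](OCc3ccccc3)[C@@H]2CO)ccc1O`) gives 41300 nM. Compound 3 (`Cc1ccc(S(=O)(=O)NCC(=O)N2Cc3ccccc3[C@@H](OCc3ccccc3)[C@@H]2CO)cc1`) carries a sulfonamide chain on the same core and gives 3800 nM, the lowest of the three numbers and clearly apart from the other two.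

Compound 4 (`Cc1ccc(S(=O)(=O)N[C@@H](C)C(=O)N2Cc3ccccc3[C@@H](OCc3ccccc3)[C@@H]2CO)cc1`) differs from compound 3 in one place: methyl in place of hydrogen on a saturated chain carbon bound to a carbonyl carbon and a sulfonamide nitrogen. This is methyl in place of hydrogen on a saturated chain carbon bound to a carbonyl carbon and a sulfonamide nitrogen.

Going by the values given here, the only measured single-place change is a 1.4-fold higher number from compound 1 to compound 2 (0.14 log units; within the scatter). It concerns a different part of the molecule, where 4-hydroxy-3-methoxyphenyl replaces 2,3-dimethoxyphenyl, so it offers only weak guidance here. Among the compounds with values here, no measured pair tests a methyl on this carbon, so the data give no direction for the change.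

The expected result in this assay is therefore no clear shift, and the estimated change is a 1.1-fold higher number from compound 3 to compound 4 (0.02 log units; within the scatter). Compound 4 is estimated at 4000 nM, with an expected range of 1500 nM to 12000 nM.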

Compound 4, half-maximal inhibitory concentration: 4670 nM
The estimate for compound 4 lay 1.2-fold (0.07 log units) below the measured number; the range from low to high includes it.
By their numbers in this assay, from the lowest: compounds 3 and 4 (each within the scatter of the next); then compounds 1 and 2 (each within the scatter of the next).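

Putting methyl in place of hydrogen on the saturated chain carbon bound to a carbonyl carbon and a sulfonamide nitrogen gives, in this assay, a 1.2-fold higher number from compound 3 to compound 4 (0.09 log units; within the scatter). Going by these compounds alone, this is the first measured change at this position, and it shows that one added carbon here produces no shift that can be told apart from the ordinary spread of repeated measurements. No measurement is available that would explain this result.

The compounds shown leave open whether an ethyl group, a longer chain, an amine or a carboxylic acid on this carbon would also leave the number in this assay unmoved. From the compounds shown here alone, the mirror-image arrangement of the methyl on this carbon also remains open, as compound 4 shows only one arrangement.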